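The source may report more compounds than this note shows. Statements on the series, on what has been measured and on what is new or still open speak of the compounds shown alone.

Measured compounds:

Compound 1, `S=C(Nc1ccccc1)N1N=C(c2ccc(Cl)cc2)CC1c1ccc2c(c1)OCCO2`: 187000 nM
Compound 2, `S=C(Nc1ccccc1)N1N=C(c2ccc(Br)cc2)CC1c1ccc2c(c1)OCCO2`: 2580 nM

Both compounds were tested in a functional assay on HT-29 cells (Homo sapiens) for antiproliferative activity, read by MTT assay, with a stated time of 48 h; on this read-out lower numbers stand for stronger inhibition of growth and higher numbers for weaker inhibition of growth. Within the data shown here, compound 2 has the lowest number of the two, and the only step measured so far, a 72-fold lower number from compound 1 to compound 2 (1.86 log units; beyond the scatter), runs to it. Compound 3, `S=C(Nc1ccccc1)N1N=C(c2ccccc2Br)CC1c1ccc2c(c1)OCCO2`, is yet to be measured. It differs from compound 2 in one place: 2-bromophenyl in place of 4-bromophenyl on a carbon with a double bond to nitrogen.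

Among the measured compounds shown here, no measured step bears directly on this change. For the measured compounds named here, the single known step swaps one halogen for another on the same aromatic carbon; it says nothing about moving a bromo group to a different carbon of the same ring while the atoms stay the same. The direction of the step from compound 2 to compound 3 therefore cannot be read from the data. With a change of this kind in a series where the halogen on that ring mattered so much, a step of some size is more plausible than none, and a weaker result seems somewhat more likely than a stronger one, though this is a guess rather than an inference.

On that basis, compound 3 is expected to give about 8000 nM, within roughly 2000 nM to 40000 nM, which would mean an estimated step of a 3.1-fold higher number from compound 2 to compound 3 (0.49 log units; beyond the scatter).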

Compound 3, concentration for 50% growth inhibition: > 200000 nM
Compound 3: a limit, no number (the forecaster's own chance of this, stated with the estimate: 5%); at least 25-fold (1.39 log units) between middle value and limit.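

In this assay, compound 3 gives > 200000 nM, which is a limit of the assay and not a number. Moving the bromo group around the ring, with the atoms of the group unchanged, gives an at least 77-fold higher number from compound 2 to compound 3 (1.88 log units; beyond the scatter), so the earlier finding that the choice of halogen matters now has a companion: in this pair, where the bromo group sits on the phenyl ring also counts, and by a large margin. The other new step, an at least 1.0-fold higher number from compound 1 to compound 3 (0.02 log units; that floor lies within the scatter), cannot be read as a real difference, and both steps give only a floor and not a true size, set by a single value: the limit of > 200000 nM in this assay, at which 1 of the 3 values shown sits.

Still open, as far as these compounds go, is whether the strong effect belongs to bromine itself or to any group of similar place on that ring, which a 4-iodophenyl, 4-methoxyphenyl or 4-aminophenyl group on the same carbon could test. Equally open, from the compounds shown here alone, is whether 2-chlorophenyl would behave like 2-bromophenyl, and whether an amine or a carboxylic acid on the phenyl of the shared core would be tolerated at all.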